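Cytotoxicity Outlook for an Ester Analogue of Compound 1

The source may report more compounds than this note shows. Statements on the series, on what has been measured and on what is new or still open speak of the compounds shown alone.

Three compounds have so far been measured in an ADME assay on HEL cells (Homo sapiens) for cytotoxicity, read by microscopy; a lower number here means that less compound is tolerated, a higher number that more compound is tolerated:

compound 1 `O=c1ccn(CCCCCOc2ccc(Br)cc2)c(=O)[nH]1`: 100000 nM
compound 2 `Nc1ccc(OCCCCCn2ccc(=O)[nH]c2=O)cc1`: > 100000 nM
compound 3 `Cc1cc(C)cc(OCCCCCn2ccc(=O)[nH]c2=O)c1`: > 100000 nM

For the measured compounds named here, compound 1 gives the only actual number in the set. The value of compound 2 is a limit of the assay, not a number. The value of compound 3 is likewise a limit. Going by the values given here, the one measured step that starts from compound 1, a number no lower from compound 1 to compound 2 (the limit leaves the size open), is therefore open in size.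

Compound 4 `CCCOC(=O)c1ccc(OCCCCCn2ccc(=O)[nH]c2=O)cc1` differs from compound 1 by propoxycarbonyl in place of bromo on an aromatic carbon. Among the compounds with values here, no measured step covers an ester group, and the step from compound 1 to compound 2 cannot be read for size, but the limit of > 100000 nM in this assay, at which 2 of the 3 values shown sit, shows where most of the set sits. No move beyond the scatter is therefore expected in this assay.

Compound 4 is expected to give 100000 nM, with a range from 40000 nM to 250000 nM. That estimate means a step of no change at the digits printed from compound 1 to compound 4 (within the scatter), expected to stay within the scatter, and quite possibly only a limit will be reported.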

Compound 4, minimum cytotoxic concentration: >= 100000 nM
Compound 4 gave a limit, no number; the forecaster's own chance of this, stated with the estimate: 60%; the middle value sits exactly at the limit.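

Putting propoxycarbonyl, with six heavy atoms, in place of the single bromine atom on this aromatic carbon gives, in this assay, a number no lower from compound 1 to compound 4 (the limit leaves the size open). Compound 4 gives >= 100000 nM, which is a limit and not a number. An ester at this position, a kind of group not covered by the earlier compounds, therefore also ends at a limit, as the amino and dimethyl-substituted compounds did: the limit of >= 100000 nM in this assay, at which 1 of the 4 values shown sits.

As far as these compounds go, the steps from compound 1 and compound 2 to compound 4 cannot be read for size, so how these compounds rank against one another remains unknown. Also open, from the compounds shown here alone, is whether a carboxylic acid or a shorter methyl ester at this position would end at a limit in this assay or give an actual number.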